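The source may hold more compounds than are shown below. What is called first, only, known or untested is meant among the compounds shown, and "the series" means these compounds.

Compound 2 `COc1cc(C(=O)/C=C/c2c(-c3ccc(F)cc3)nc3ncccn23)cc(OC)c1OC` was tested in a functional assay on SR cells (Homo sapiens) for inhibition, read by sulforhodamine B assay, with a stated time of 48 h (a higher number here means a weaker inhibitor of growth, a lower number a stronger inhibitor of growth), where compound 2 gives 2280 nM. Compound 1 `COc1cc(C(=O)/C=C/c2c(-c3cccs3)nc3ccccn23)cc(OC)c1OC` gives 1230 nM in the same assay, and these two numbers lie within the usual scatter of each other, so neither compound can be set apart from the other. Compound 3 `COc1ccc(-c2nc3ncccn3c2/C=C/C(=O)c2cc(OC)c(OC)c(OC)c2)cc1` has not yet been measured. It differs from compound 2 in one place: methoxy in place of fluoro on an aromatic carbon. Within the data shown here, no measured pair of compounds shows this particular change, so the size of its effect is unknown. Compound 3 is expected to give about 1500 nM, within a range of 500 nM to 5000 nM. The expected step of a 1.5-fold lower number from compound 2 to compound 3 (0.18 log units; within the scatter) would stay within the scatter.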

Compound 3, concentration for 50% growth inhibition: 1530 nM
Beside the measured number, compound 3's estimate is 1.0-fold (0.01 log units) below it; the measured number falls inside the stated range.
By their numbers in this assay, from the lowest: compounds 1, 3 and 2 (each within the scatter of the next).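

Among these compounds, compound 2 and compound 3 give the first measured change at one place in this set. Going from 4-fluorophenyl to 4-methoxyphenyl gives a 1.5-fold lower number from compound 2 to compound 3 (0.17 log units; within the scatter) and so, in this assay, the two compounds cannot be told apart, and either group is tolerated here. Nothing available explains this result.

Going by these compounds, whether an amine or a carboxylic acid on this aromatic carbon would give a step beyond the scatter remains open. So does the result for a longer chain, such as butoxy, in place of methoxy.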